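Two Alkylations on a Weak Aorta Series

This account rests on a few compounds, and the source may have more. Where it says the series, first, only, none or still open, it means among the compounds named here.

Measured compounds:
Compound 1, `COc1nc(-c2cc3ccccc3o2)cc(-c2cccc3ccccc23)c1C#N`, gives 359000 nM in a functional assay on aorta (strain Wistar) for inhibition, with Thoracic aorta (Rattus norvegicus) as the target; on this read-out higher numbers stand for weaker inhibition and lower numbers for stronger inhibition.
Compound 2, `CCOc1nc(-c2cc3ccccc3o2)cc(-c2cccc3ccccc23)c1C#N`, gives 344000 nM.
Compound 3, `COc1nc(-c2cc3ccccc3o2)cc(-c2cn(C)c3ccccc23)c1C#N`, gives 262000 nM.

Compound 4, `CCn1cc(-c2cc(-c3cc4ccccc4o3)nc(OC)c2C#N)c2ccccc21`, has not yet been measured. It differs from compound 3 by methyl in place of hydrogen on a saturated chain carbon bound to an aromatic nitrogen. The same kind of change, a hydrogen exchanged for a methyl, already connects two measured compounds: compound 2 differs from compound 1 by methyl in place of hydrogen on a saturated chain carbon bound to an oxygen on an aromatic ring. That step gave a 1.0-fold lower number from compound 1 to compound 2 (0.02 log units; within the scatter). The places differ, though: in the earlier pair the chain carbon is bound to an oxygen on an aromatic ring, in the new pair to an aromatic nitrogen. How the core of compound 3 differs from the core of compound 1 is not broken down here. Resting on the small earlier step, the expected step is a 1.0-fold lower number from compound 3 to compound 4 (0.02 log units; within the scatter). Compound 4 is estimated at 250000 nM, likely between 120000 nM and 500000 nM.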

Compound 4, half-maximal inhibitory concentration: 299000 nM
The estimate for compound 4 lay 1.2-fold (0.08 log units) below the measured number, within the range that was stated.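

In this assay the change from methyl to ethyl on the aromatic nitrogen gives a 1.1-fold higher number from compound 3 to compound 4 (0.06 log units; within the scatter) and so leaves the number where it was. This does not show that the change is without effect on every core, for the two steps sit at different places and only two cores are shown. What it does show is that in both cases this small extension made no readable difference, and that the two steps agree: the same change on two cores in this assay, a 1.0-fold lower number (0.02 log units; within the scatter) from compound 1 to compound 2 and a 1.1-fold higher number (0.06 log units; within the scatter) from compound 3 to compound 4, 1.2-fold (0.08 log units) apart, within the scatter of two such steps

The compounds shown leave open whether a longer chain, such as propyl or butyl, at either place would shift the number beyond the scatter. They also leave open what an amine or a carboxylic acid at the end of that chain would do.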